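The compounds below may be only part of what the source reports. "The series", "measured", "known", "first", "only" and "open" are said of these compounds alone.

In an ADME assay on L132 cells (Homo sapiens) for cytotoxicity, read by MTT assay, with a stated time of 72 h (on this read-out higher numbers stand for weaker inhibition and lower numbers for stronger inhibition), compound 1 (`COc1ccc(C2=C(c3cc(OC)c(OC)c(OC)c3)C(=O)C(OC(C)=O)C2)cc1`) gives > 100 ug/mL as a limit of the assay. Compound 2 (`COc1ccc(C2=C(c3cc(OC)c(OC)c(OC)c3)C(=O)C(O)C2)cc1`) gives < 1 ug/mL as a limit too, the lower of the two values shown. Compound 3 (`COc1ccc(C2=C(c3cc(OC)c(OC)c(OC)c3)C(=O)C(O)C2)cc1Cl`) differs from compound 2 by a single change (chloro in place of hydrogen on an aromatic carbon). Going by the values given here, the only measured step (an at least 100-fold lower number from compound 1 to compound 2 (2.00 log units; beyond the scatter)) was large, but it puts hydrogen in place of acetyl on an oxygen on a saturated carbon, a different change, so it gives no direct guide here. No step beyond the scatter is therefore expected in this assay (a step that the limit leaves unreadable from compound 2 to compound 3). Compound 3 is estimated at 0.5 ug/mL (expected range 0.1 ug/mL to 2 ug/mL).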

Compound 3, half-maximal inhibitory concentration: < 1 ug/mL
Compound 3: only a limit was reported; the forecaster's own chance of this, stated with the estimate: 75%; the middle value lies beyond the limit too.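

Going by these compounds alone, compound 2 and compound 3 are both reported only as limits in this assay, so no step between them can be read. Going by these compounds, whether chloro in place of hydrogen changes the result remains open.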